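A few compounds are considered here, and "the series" means these few. Any claim that something is new, unique, unknown or untested is made for them only; others in the source may bear on it.

Two compounds share one core and differ only in the group on the aromatic nitrogen of the six-membered ring. Compound 1 `O=C(Nc1ccc(Oc2ccnc3[nH]ccc23)c(F)c1)c1nn(-c2ccc(Br)cc2)ccc1=O` carries a bromo on that phenyl; in a functional assay on HepG2 cells (Homo sapiens) for cytotoxicity, read by MTT assay, with a stated time of 72 h (a lower number here means a stronger inhibitor, a higher number a weaker inhibitor), compound 1 gives 68000 nM. Compound 2 `O=C(Nc1ccc(Oc2ccnc3[nH]ccc23)c(F)c1)c1nn(-c2ccccc2)ccc1=O` carries a plain phenyl, and in this assay compound 2 gives 24900 nM. Within the data shown here, the single measured step is a 2.7-fold lower number from compound 1 to compound 2 (0.44 log units; beyond the scatter). Among the measured compounds shown here, of the two numbers, compound 2 holds the lowest, with compound 1 as its only neighbour. Compound 3 `O=C(Nc1ccc(Oc2ccnc3[nH]ccc23)c(F)c1)c1nn(-c2ccc(Cl)c(F)c2)ccc1=O` brings a new variant: 4-chloro-3-fluorophenyl in place of phenyl on an aromatic nitrogen. This change puts halogen back onto the phenyl, the reverse of what the measured step took away, and that step was modest in size. A modest rise in this assay is therefore expected, a 1.8-fold higher number from compound 2 to compound 3 (0.26 log units; within the scatter). For compound 3 the value in this assay is estimated at 45000 nM, most likely between 20000 nM and 100000 nM.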

Compound 3, half-maximal inhibitory concentration: 9610 nM
Compound 3: the middle estimate sits 4.7-fold (0.67 log units) above what was measured; the whole stated range lies above it.
By their numbers in this assay, from the lowest: compound 3; then compound 2; then compound 1.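

In this assay, halogen on this phenyl does not push the number in one direction. Compound 1, with its bromo, reads higher than compound 2, yet 4-chloro-3-fluorophenyl in place of phenyl gives a 2.6-fold lower number from compound 2 to compound 3 (0.41 log units; beyond the scatter) and, set against the bromo group, gives a 7.1-fold lower number from compound 1 to compound 3 (0.85 log units; beyond the scatter). This puts compound 3 lowest of the three, with both of its steps beyond the scatter, and nothing shown here accounts for the difference between these halogen patterns.

As far as these compounds go, compound 3 adds chloro and fluoro together, so what either halogen would do alone stays open. Also open, from the compounds shown here alone, is whether an amine or a carboxylic acid on this phenyl would move the number in the same direction as 4-chloro-3-fluorophenyl.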